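Swapping the aromatic substituent: bromo for methoxy

A few compounds are considered here, and "the series" means these few. Any claim that something is new, unique, unknown or untested is made for them only; others in the source may bear on it.

Measured so far in a functional assay on MCF7 cells (Homo sapiens) for inhibition, read by MTT assay, with a stated time of 72 h; a higher number here means a weaker inhibitor, a lower number a stronger inhibitor:
compound 1 `Cc1ccc(C(=O)OC2(C(=O)Nc3ccc([N+](=O)[O-])cc3)CCCCC2)cc1` gives 9.8 nM
compound 2 `O=C(OC1(C(=O)Nc2ccc([N+](=O)[O-])cc2)CCCCC1)c1ccc(Cl)cc1` gives 15 nM
compound 3 `COc1ccc(C(=O)OC2(C(=O)Nc3ccc([N+](=O)[O-])cc3)CCCCC2)cc1` gives 41.2 nM

Compound 3 stands at the highest number of the three. The step of a 4.2-fold higher number from compound 1 to compound 3 (0.62 log units; beyond the scatter) and the step of a 2.7-fold higher number from compound 2 to compound 3 (0.44 log units; beyond the scatter) both lie beyond the scatter, whereas the step of a 1.5-fold higher number from compound 1 to compound 2 (0.18 log units; within the scatter) lies within it, so methyl and chloro at this position cannot be told apart on these numbers.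

Compound 4 `O=C(OC1(C(=O)Nc2ccc([N+](=O)[O-])cc2)CCCCC1)c1ccc(Br)cc1` differs from compound 3 in one place: bromo in place of methoxy on an aromatic carbon. The measured step that bears most directly on this change is a 2.7-fold higher number from compound 2 to compound 3 (0.44 log units; beyond the scatter), which introduced methoxy in place of a halogen and raised the number modestly; compound 4 runs that exchange the other way with a different halogen. Going by these compounds, no chloro-to-bromo comparison exists, so the size of any halogen-to-halogen difference is unknown here. A lower number is therefore expected, in the region of compound 2. The expected step for compound 4 is a 2.9-fold lower number from compound 3 to compound 4 (0.47 log units; beyond the scatter). Compound 4 is estimated at 14 nM, with a range from 6 nM to 35 nM.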

Compound 4, half-maximal inhibitory concentration: 237 nM
Compound 4: the middle estimate sits 17-fold (1.23 log units) below what was measured; measured number outside the range, above it.
By their numbers in this assay, from the lowest: compounds 1 and 2 (each within the scatter of the next); then compound 3; then compound 4.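

Bromo and chloro do not behave as one halogen class at this position, on an aromatic carbon para to a large group: the change between them gives a large step (a 16-fold higher number from compound 2 to compound 4 (1.20 log units; beyond the scatter)), although methyl and chloro could not be told apart among the earlier compounds. Bromo also stands clear of the other two groups (a 5.8-fold higher number from compound 3 to compound 4 (0.76 log units; beyond the scatter); a 24-fold higher number from compound 1 to compound 4 (1.38 log units; beyond the scatter)), so compound 4, not compound 3 with its methoxy, now marks the weak end of the series, and the position is sensitive to a single-atom exchange. No measurement at hand accounts for this jump.

Going by these compounds, whether fluoro or iodo would fall with chloro or with bromo remains open, and the halogen contrast rests on a single pair. On these data alone, how an amine or a carboxylic acid at this position would compare also remains unknown.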